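Nitro to Trifluoromethyl on the Phenyl: Estimating Compound 4

The source may report more compounds than this note shows. Statements on the series, on what has been measured and on what is new or still open speak of the compounds shown alone.

Measured compounds, with their values in a functional assay on RT-112 cells (Homo sapiens) for antiproliferative activity, read by MTT assay, with a stated time of 72 h; a lower number here means a stronger inhibitor of growth, a higher number a weaker inhibitor of growth:
Compound 1 `COc1cc(Nc2ncnc3c(NC(=O)Nc4cccc(Oc5ccccc5)c4)cccc23)cc(OC)c1` gives 14000 nM.
Compound 2 `COc1cc(Nc2ncnc3c(NC(=O)Nc4ccc(C)c(C)c4)cccc23)cc(OC)c1` gives 8.8 nM.
Compound 3 `COc1cc(Nc2ncnc3c(NC(=O)Nc4ccc([N+](=O)[O-])cc4)cccc23)cc(OC)c1` reaches only the limit of > 20000 nM, so no number is known for it.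

Compound 3 therefore stands at the weak end of the three in this assay, at the limit of > 20000 nM in this assay, at which 1 of the 3 values shown sits. Compound 4 `COc1cc(Nc2ncnc3c(NC(=O)Nc4ccc(C(F)(F)F)cc4)cccc23)cc(OC)c1` differs from it by trifluoromethyl in place of nitro on an aromatic carbon. Among the measured compounds shown here, the only measured step that touches this position is an at least 2200-fold higher number from compound 2 to compound 3 (3.35 log units; beyond the scatter), which moved from a strong inhibitor to the limit, but it swaps a different pair of groups, so it gives only a loose guide. The trifluoromethyl compound is expected to fall somewhere between those extremes: compound 4 is estimated at 5000 nM (range 500 nM to 20000 nM), an expected step of an at least 4.0-fold lower number from compound 3 to compound 4 (0.60 log units; beyond the scatter).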

Compound 4, concentration for 50% growth inhibition: 3920 nM
Beside the measured number, compound 4's estimate is 1.3-fold (0.11 log units) above it; the range from low to high includes it.
By their numbers in this assay, from the lowest: compound 2; then compound 4; then compound 1. At a limit, above all of these: compound 3.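

In this assay, trifluoromethyl in place of nitro gives a measurable number where there was only a limit, with an at least 5.1-fold lower number from compound 3 to compound 4 (0.70 log units; beyond the scatter). That gain still leaves the compound far from the 3,4-dimethylphenyl compound, with a 450-fold higher number from compound 2 to compound 4 (2.65 log units; beyond the scatter), so swapping this one group does not restore strong growth inhibition. Going by these compounds, compound 3 stands only at a limit, so the true size of the first step stays unknown: the limit of > 20000 nM in this assay, at which 1 of the 4 values shown sits. Open, on these data alone, is how an amine or a chlorine at this same place on the phenyl ring would compare with trifluoromethyl.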